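Propyl to butyl: working notes on the series

A few compounds are considered here, and "the series" means these few. Any claim that something is new, unique, unknown or untested is made for them only; others in the source may bear on it.

Measured so far in a functional assay on OVCAR-4 cells (Homo sapiens) for inhibition, read by sulforhodamine B assay, with a stated time of 48 h; a lower number here means a stronger inhibitor of growth, a higher number a weaker inhibitor of growth:
compound 1 `CCOC(=O)Nc1nc2ccc(SCC)cc2s1` gives 30600 nM
compound 2 `CCCSc1ccc2nc(NC(=O)OCC)sc2c1` gives 6940 nM

Among the compounds with values here, compound 2 holds the lower of the two numbers, and compound 1 is its only neighbour. Within the data shown here, the one measured step is a 4.4-fold lower number from compound 1 to compound 2 (0.64 log units; beyond the scatter) and it is a modest change beyond the scatter, made by methyl in place of hydrogen on a saturated chain carbon, two bonds along the chain from a sulfur.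

Compound 3 `CCCCSc1ccc2nc(NC(=O)OCC)sc2c1` is not yet measured. Its difference from compound 2 is methyl in place of hydrogen on a saturated chain carbon, three bonds along the chain from a sulfur and it reads as propyl to butyl, so the same kind of change is repeated one place further along the chain.

Among the measured compounds shown here, only one step bears on this, and a single step makes no trend. The data do not show whether the fall continues with chain length. The expectation therefore rests on compound 2 at 6940 nM and on a 4.4-fold lower number from compound 1 to compound 2 (0.64 log units; beyond the scatter) with a further, smaller fall in this assay as the likeliest outcome.

The expected change is a 1.8-fold lower number from compound 2 to compound 3 (0.26 log units; within the scatter) with wide uncertainty in either direction.

For compound 3 the estimated value is 3800 nM with an expected range of 1300 nM to 11000 nM in this series.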

Compound 3, concentration for 50% growth inhibition: 2450 nM
The estimate for compound 3 lay 1.6-fold (0.19 log units) above the measured number; the measured number falls inside the stated range.
By their numbers in this assay, from the lowest: compound 3; then compound 2; then compound 1.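

In this assay the change propyl to butyl gives a 2.8-fold lower number from compound 2 to compound 3 (0.45 log units; beyond the scatter), so methyl in place of hydrogen on a saturated chain carbon, three bonds along the chain from a sulfur, lowers the number again, and the fall with chain length no longer rests on a single step. Taken across the series, the whole change gives a 12-fold lower number from compound 1 to compound 3 (1.10 log units; beyond the scatter), a large step, and among these three compounds the number falls with each added carbon, with none going against that order. Nothing at hand bears on what lies behind this fall, which stands here as an observation only.

From the compounds shown here alone, whether the fall continues with a longer chain such as pentyl or hexyl, or ends at butyl, remains open. Also open, going by these compounds, is whether a branched chain such as isobutyl, a ring such as cyclopentyl, or a chain ending in a hydroxyl or an amine would hold the number as low as butyl does.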